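The source may hold more compounds than are shown below. What is called first, only, known or untested is meant among the compounds shown, and "the series" means these compounds.

Measured in a functional assay on MCF7 cells (Homo sapiens) for antiproliferative activity, read by MTT assay, with a stated time of 48 h; on this read-out higher numbers stand for weaker inhibition and lower numbers for stronger inhibition:
- compound 1 `CC(C)=CCC[C@]1(C)/C=C/[C@@H](OC(=O)C=C(C)C)[C@](C)(O)/C=C/C(=O)/C(C=O)=C\C1`: 12600 nM
- compound 2 `CC(C)=CCC[C@]1(C)/C=C/[C@@H](OC(=O)C=C(C)C)[C@](C)(O)/C=C/C(=O)/C(CCl)=C\C1`: 610 nM
- compound 3 `CC(C)=CCC[C@]1(C)/C=C/[C@@H](OC(=O)C=C(C)C)[C@](C)(O)/C=C/C(=O)/C(C[Si](C)(C)C(C)(C)C)=C\C1`: 6040 nM

Compound 3 stands in the middle of these three, with a 2.1-fold lower number from compound 1 to compound 3 (0.32 log units; beyond the scatter) and a 9.9-fold higher number from compound 2 to compound 3 (1.00 log units; beyond the scatter) on either side of it.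

Compound 4 `CSC(=S)OC/C1=C/C[C@](C)(CCC=C(C)C)/C=C/[C@@H](OC(=O)C=C(C)C)[C@](C)(O)/C=C/C1=O` keeps the shared core of compound 3 and carries one change: a group of 5 heavy atoms (2 carbon, 1 oxygen, 2 sulfur; no ring) in place of a group of 7 heavy atoms (6 carbon, 1 silicon; no ring), on a saturated chain carbon bound to a double-bonded ring carbon.

Within the data shown here, two measured steps bear most directly on this change. The step of a 9.9-fold higher number from compound 2 to compound 3 (1.00 log units; beyond the scatter) involved the same saturated chain carbon, and it shows that the group held there can shift the number substantially. The step of a 21-fold lower number from compound 1 to compound 2 (1.32 log units; beyond the scatter) shows a large drop when the chloromethyl group is present. Among the measured compounds shown here, no measured compound carries the entering group, so these steps offer only a rough guide. Removing the silicon-containing group from compound 3 at 6040 nM therefore points to a modest fall, not a large one, and a result close to compound 3 remains possible.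

The step expected is a 2.4-fold lower number from compound 3 to compound 4 (0.38 log units; beyond the scatter).

The estimate for compound 4 is 2500 nM, with an expected range from 700 nM to 9000 nM.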

Compound 4, half-maximal inhibitory concentration: 900 nM
For compound 4 the middle estimate is 2.8-fold (0.44 log units) above the measured one, and the stated range covers the measured number.
By their numbers in this assay, from the lowest: compounds 2 and 4 (each within the scatter of the next); then compound 3; then compound 1.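

On this saturated chain carbon, the group held there clearly matters in this assay: replacing the silicon-containing group with the sulfur-containing one gives a 6.7-fold lower number from compound 3 to compound 4 (0.83 log units; beyond the scatter), closing most of the gap that had separated the silicon-containing group from chlorine. The sulfur-containing group and chlorine cannot be told apart, with a 1.5-fold higher number from compound 2 to compound 4 (0.17 log units; within the scatter), so two very different groups now give results within the usual scatter of each other, and the formyl compound remains well apart, as a 14-fold lower number from compound 1 to compound 4 (1.15 log units; beyond the scatter) shows. Nothing shown here explains these differences.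

The compounds shown leave open how a hydroxyl group or an amine would behave on this carbon. They also leave open whether a longer carbon chain would give a number closer to that of compound 3 or compound 4.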